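Taking the phenyl away from compound 1

A few compounds are considered here, and "the series" means these few. Any claim that something is new, unique, unknown or untested is made for them only; others in the source may bear on it.

Measured in a functional assay on MDA-MB-231 cells (Homo sapiens) for cytotoxicity, read by MTT assay, with a stated time of 72 h; on this read-out higher numbers stand for weaker inhibition and lower numbers for stronger inhibition:
- compound 1 `N=C(Nc1cccc(C(F)(F)F)c1)c1cc2c(-c3ccccc3)n[nH]c2cn1`: 22300 nM
- compound 2 `N=C(Nc1ccccc1)c1cc2c(-c3ccccc3)n[nH]c2cn1`: 11000 nM

Compound 1, at 22300 nM, stands highest of the two numbers, with compound 2 as its nearest neighbour. The next structure is compound 3 `N=C(Nc1cccc(C(F)(F)F)c1)c1cc2cn[nH]c2cn1`, reached by hydrogen in place of phenyl on an aromatic carbon of a five-membered aromatic ring with 2 nitrogen. Within the data shown here, only one measured step exists, a 2.0-fold lower number from compound 1 to compound 2 (0.31 log units; beyond the scatter), and it is modest. It concerns the trifluoromethyl and not the phenyl, so it bears only loosely, as a rough gauge of how far one change moves these numbers. Among the measured compounds shown here, no measurement yet shows what the phenyl contributes. In this assay, a moderate step towards a higher number is therefore expected, with wide uncertainty, and a step in the other direction is not excluded. The estimated change is a 1.8-fold higher number from compound 1 to compound 3 (0.25 log units; within the scatter). For compound 3, the expected value is 40000 nM, within an estimated range of 15000 nM to 100000 nM.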

Compound 3, half-maximal inhibitory concentration: > 50000 nM
Compound 3: no number, only a limit; the forecaster's own chance of this, stated with the estimate: 30%; at least 1.2-fold (0.09 log units) between middle value and limit.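

In this assay compound 3 gives no number, only a limit of the assay, > 50000 nM. Hydrogen in place of phenyl on an aromatic carbon of a five-membered aromatic ring with 2 nitrogen gives an at least 2.2-fold higher number from compound 1 to compound 3 (0.35 log units; beyond the scatter), the first measured change at this position and one that moves the read-out towards weaker inhibition. The step is bounded on one side only, so its true size stays unknown: the limit of > 50000 nM in this assay, at which 1 of the 3 values shown sits.

As far as these compounds go, only hydrogen and phenyl are compared at this carbon, so whether a methyl, an amine or a carboxylic acid there would keep the value of compound 1 stays open. From the compounds shown here alone, whether taking away the trifluoromethyl changes the read-out in the same way when the phenyl is absent also stays open.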